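Swapping the Dimethoxyphenyl End for Chlorophenyl

This account rests on a few compounds, and the source may have more. Where it says the series, first, only, none or still open, it means among the compounds named here.

Compound 1, `COc1cc(OC)c(OC)cc1/C=C/COC(=O)/C=C/c1ccc(OC)c(OC)c1`: 75%
Compound 2, `COc1cccc(/C=C/C(=O)OC/C=C/c2cc(OC)c(OC)cc2OC)c1`: 75%

Both compounds were tested in a functional assay on the whole organism (strain Kunming) with Mus musculus as the target, with a stated time of 0.5 h, at a dose of 300 mg/kg by the intraperitoneal route; a higher number here means a weaker effect of the compound at the dose given, a lower number a stronger effect. Compound 1 stands level with compound 2 on the read-out shown: the only measured step, no change at the digits printed from compound 1 to compound 2 (within the scatter), stays within the scatter of repeated measurements.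

Compound 3, `COc1cc(OC)c(OC)cc1/C=C/COC(=O)/C=C/c1ccc(Cl)cc1`, has not yet been measured. It differs from compound 1 by 4-chlorophenyl in place of 3,4-dimethoxyphenyl on a double-bonded chain carbon bound to a double-bonded chain carbon. Going by the values given here, the one measured step touches the same aromatic ring, removing a single methoxy, and it left the read-out unchanged. Among the compounds with values here, no measured step covers the full exchange to 4-chlorophenyl, so the expectation rests on that partial precedent alone. For compound 3 the expected step is no change at the digits printed from compound 1 to compound 3 (within the scatter), a change that is not expected to exceed the scatter. The estimate for compound 3 is 75%, with a range from 55% to 90%.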

Compound 3, a percentage reported as activity, at one dose (the size of the read-out at that dose, not a potency): 50%
The estimate for compound 3 lay 25 percentage points above the measured number, outside the stated range (below it).
By their numbers in this assay, from the lowest: compound 3; then compounds 1 and 2 (each within the scatter of the next).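

In this assay, 4-chlorophenyl in place of 3,4-dimethoxyphenyl gives a number 25 percentage points lower from compound 1 to compound 3 (beyond the scatter) and 4-chlorophenyl in place of 3-methoxyphenyl gives a number 25 percentage points lower from compound 2 to compound 3 (beyond the scatter), and a lower number here means a stronger effect at the dose given. Going by these compounds alone, the earlier pair showed only that this ring could lose one methoxy with no visible shift, whereas these steps show that the read-out does respond to a larger exchange at this position. Nothing measured here accounts for the stronger effect.

The compounds shown leave open whether the chlorine or the absence of methoxy groups goes with this step, as both change together. A plain phenyl ring or a 4-aminophenyl group at this position would help to separate the two.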